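Swapping the hydrazone aryl group on the pyrazole carbohydrazide

The compounds below may be only part of what the source reports. "The series", "measured", "known", "first", "only" and "open" are said of these compounds alone.

Of the compounds shown here, two have been measured in a functional assay on A549 cells (Homo sapiens) for antiproliferative activity, read by BrdU incorporation, with a stated time of 48 h; a lower number here means a stronger inhibitor, a higher number a weaker inhibitor. Compound 1 `CC(C)(C)c1ccc(Cn2nc(-c3ccc(Cl)cc3)cc2C(=N)NO)cc1` gives 17000 nM. Compound 2 `O=C(N/N=C/c1cccc(O)c1O)c1cc(-c2ccc(Cl)cc2)nn1Cc1ccc(Cl)nc1` gives 700 nM, the lowest of the two numbers, and its gap to compound 1 lies well beyond the scatter. Compound 3 `O=C(N/N=C/c1ccc(F)cc1F)c1cc(-c2ccc(Cl)cc2)nn1Cc1ccc(Cl)nc1` keeps the core of compound 2 and differs from it only in one place: 2,4-difluorophenyl in place of 2,3-dihydroxyphenyl on a carbon with a double bond to nitrogen. Both groups hold the same count of heavy atoms, but the entering group carries no hydrogen-bond donors or acceptors where the leaving group carried two of each. For the measured compounds named here, no measured pair tells how this assay responds to such a swap, so the expectation rests on compound 2 alone. Compound 3 is expected to give a higher number, and the estimated step of a 2.9-fold higher number from compound 2 to compound 3 (0.46 log units; beyond the scatter) is modest, just beyond the scatter. Compound 3 is thus estimated at 2000 nM, within a range from 600 nM to 7000 nM.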

Compound 3, half-maximal inhibitory concentration: 9050 nM
For compound 3 the middle estimate is 4.5-fold (0.66 log units) below the measured one; the whole stated range lies below it.
By their numbers in this assay, from the lowest: compound 2; then compounds 3 and 1 (each within the scatter of the next).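

In this assay, the aryl group on a carbon with a double bond to nitrogen proves far from neutral: 2,4-difluorophenyl in place of 2,3-dihydroxyphenyl brings a 13-fold higher number from compound 2 to compound 3 (1.11 log units; beyond the scatter) and counts as a large change. The heavy-atom count and the six-membered aromatic ring stay the same, so the step arises without any change in either; the two oxygens give way to two fluorines, and the hydrogen-bond donors and acceptors fall to none. No evidence at hand explains why this swap costs so much.

For the compounds shown here, the single pair changes the atoms and their ring locations together, so it cannot separate these two effects. It also leaves open how a phenyl group bearing one hydroxyl, or two methoxy groups, would behave here.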